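A few compounds are considered here, and "the series" means these few. Any claim that something is new, unique, unknown or untested is made for them only; others in the source may bear on it.

Of the compounds shown here, three have so far been tested in a functional assay on HepG2 cells (Homo sapiens) for inhibition, read by sulforhodamine B assay, with a stated time of 24 h; a higher number here means a weaker inhibitor, a lower number a stronger inhibitor. Compound 1, `Nc1ncnc2c1c(-c1ccccc1)cn2-c1ccc(S(=O)(=O)Nc2nccs2)cc1`, gives 4240 nM in this assay. Compound 2, `Nc1ncnc2c1c(-c1ccccc1)cn2-c1ccc(S(=O)(=O)Nc2ccccn2)cc1`, is built on the same core as compound 1 and differs from it in one place only: pyridin-2-yl in place of 1,3-thiazol-2-yl on a sulfonamide nitrogen. In this assay compound 2 gives 4090 nM. The exchange produced a 1.0-fold lower number from compound 1 to compound 2 (0.02 log units; within the scatter), so the two compounds cannot be distinguished on this read-out. Compound 3, `N#Cc1c(-c2ccccc2)cn(-c2ccc(S(=O)(=O)Nc3nccs3)cc2)c1NC(=O)CCC(=O)O`, carries a different core; the difference between the core of compound 3 and the core of compound 1 is not broken down here. In this assay compound 3 gives 3750 nM, a number that lies within the scatter of both compound 1 and compound 2, so none of the three measured compounds stands apart from the others.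

Compound 4, `N#Cc1c(-c2ccccc2)cn(-c2ccc(S(=O)(=O)Nc3ccccn3)cc2)c1NC(=O)CCC(=O)O`, has not yet been measured. It relates to compound 3 as compound 2 relates to compound 1: pyridin-2-yl in place of 1,3-thiazol-2-yl on a sulfonamide nitrogen. The surroundings of the exchanged group are described in exactly the same words for both pairs, so this is the same change carried out on a different core. Because the same change gave a 1.0-fold lower number from compound 1 to compound 2 (0.02 log units; within the scatter) on the core of compound 1, the expectation is that the number will again hardly move. On that basis compound 4 is expected to show a 1.0-fold lower number from compound 3 to compound 4 (0.01 log units; within the scatter) in this assay. The estimated value for compound 4 is 3700 nM, with a likely range from 2000 nM to 7000 nM.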

Compound 4, half-maximal inhibitory concentration: 3750 nM
The estimate for compound 4 lay 1.0-fold (0.01 log units) below the measured number, within the range that was stated.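

Placing pyridin-2-yl where 1,3-thiazol-2-yl stood on the sulfonamide nitrogen of the core of compound 3 gives no change at the digits printed from compound 3 to compound 4 (within the scatter) in this assay. Set beside the same exchange on the core of compound 1, the new step agrees with the earlier one: the same change on two cores in this assay, a 1.0-fold lower number (0.02 log units; within the scatter) from compound 1 to compound 2 and no change at the digits printed (within the scatter) from compound 3 to compound 4, 1.0-fold (0.02 log units) apart, within the scatter of two such steps On these two cores, then, the exchange behaves alike in leaving the number where it was, but this shows only that two closely matched aromatic rings cannot be told apart on this read-out, not that the group on the sulfonamide nitrogen is unimportant or that any change there would carry over between cores in the same way.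

The compounds shown leave open whether a quite different group on that nitrogen, such as a methyl group, a longer alkyl chain or a simple hydrogen in place of the ring, would move the number at all. They also leave open whether a change that does produce a clear step on one of these cores would produce a step of the same size on the other, and whether the silence of this exchange would hold on a third core.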